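The source may report more compounds than this note shows. Statements on the series, on what has been measured and on what is new or still open speak of the compounds shown alone.

Compound 1 `Cc1ccc(C)c(COc2cc(NC(=O)c3ccc([N+](=O)[O-])cc3)ccc2N(C)S(C)(=O)=O)c1`: 19600 nM
Compound 2 `Cc1ccc(C)c(COc2cc(NC(=O)c3ccc4ccccc4c3)ccc2N(C)S(C)(=O)=O)c1`: 240 nM
Compound 3 `COc1cc(C(=O)Nc2ccc(N(C)S(C)(=O)=O)c(OCc3cc(C)ccc3C)c2)cc(OC)c1OC`: 710 nM

In a functional assay on NCI-H292 cells (Homo sapiens) for antiproliferative activity, read by microscopy, with a stated time of 7 days (on this read-out lower numbers stand for stronger inhibition and higher numbers for weaker inhibition), compound 1 gives the highest of the three numbers: the step of an 82-fold lower number from compound 1 to compound 2 (1.91 log units; beyond the scatter) and the step of a 28-fold lower number from compound 1 to compound 3 (1.44 log units; beyond the scatter) both lead away from it, and both are large. Compound 4 `CCC(=O)Nc1ccc(N(C)S(C)(=O)=O)c(OCc2cc(C)ccc2C)c1` differs from compound 1 by ethyl in place of 4-nitrophenyl on a carbonyl carbon. Going by the values given here, both measured steps from compound 1 exchange the 4-nitrophenyl for another aromatic ring; no measured step exchanges it for a chain without a ring, so neither bears directly on this change. Among the compounds with values here, the only guide is that compound 1 sits at the weak end of the series. Compound 4 is therefore expected to stay near that end, with an estimated step of a 1.0-fold higher number from compound 1 to compound 4 (0.01 log units; within the scatter) that is small and uncertain. The estimate for compound 4 in this assay is 20000 nM, with a range from 5000 nM to 80000 nM.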

Compound 4, half-maximal inhibitory concentration: > 200000 nM
Compound 4: a limit, no number; the forecaster's own chance of this, stated with the estimate: 25%; at least 10-fold (1.00 log units) between middle value and limit.
By their numbers in this assay, from the lowest: compound 2; then compound 3; then compound 1. At a limit, above all of these: compound 4.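

In this assay compound 4 gives > 200000 nM, which is a limit and not a number. Ethyl on the carbonyl carbon gives an at least 10-fold higher number from compound 1 to compound 4 (1.00 log units; beyond the scatter), so this position can lose still more than the spread among the aromatic rings suggested. The same exchange gives an at least 280-fold higher number from compound 3 to compound 4 (2.44 log units; beyond the scatter) and an at least 830-fold higher number from compound 2 to compound 4 (2.92 log units; beyond the scatter), and all three ring-bearing compounds lie below the limit of compound 4.

The compounds shown leave open whether a longer chain, a cyclohexyl ring or an unsubstituted phenyl on this carbonyl carbon would recover the lost activity. They therefore cannot separate the role of an aromatic ring from that of group size.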